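From amino to anilino at the assay limit

The compounds below may be only part of what the source reports. "The series", "measured", "known", "first", "only" and "open" are said of these compounds alone.

In a functional assay on L5178Y cells (Mus musculus) for inhibition, read by MTT assay, with a stated time of 24 h (on this read-out lower numbers stand for stronger inhibition and higher numbers for weaker inhibition), compound 3 (`COc1cc(O)c2c(c1)O[C@H](c1ccc(O)cc1)C/C2=N\N`) gives >= 11300 nM, which is a limit and not a number. Compound 1 (`Oc1ccc([C@@H]2C/C(=N\Nc3ccccc3)c3c(O)cc(O)cc3O2)cc1`) gives >= 11300 nM, also a limit. Compound 2 (`COc1cccc(/C=N/N=C2\C[C@@H](c3ccc(O)cc3)Oc3cc(OC)cc(O)c32)c1`) gives >= 11300 nM, again a limit. Compound 3 therefore has no numerical position of its own, and the whole set shares (the limit of >= 11300 nM in this assay, at which 3 of the 3 values shown sit).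

Compound 4 (`COc1cc(O)c2c(c1)O[C@H](c1ccc(O)cc1)C/C2=N\Nc1ccccc1`) differs from compound 3 by phenyl in place of hydrogen on an amine nitrogen, in words phenyl in place of hydrogen on an amine nitrogen, or amino to anilino. Among the measured compounds shown here, the only measured step bearing on this is a step that the two limits leave unreadable from compound 2 to compound 3, which removes a larger group carrying an aromatic ring, so it offers no size to carry over. No step beyond the scatter is expected in this assay. Compound 1 stands at the limit >= 11300 nM. The expected change is a step that the limit leaves unreadable from compound 3 to compound 4, in the direction of slightly weaker inhibition and within the scatter. Compound 4 is estimated at 16000 nM, with an expected range of 7000 nM to 40000 nM, and most likely it too will be reported only as a limit.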

Compound 4, half-maximal inhibitory concentration: >= 11300 nM
Compound 4: only a limit was reported; the forecaster's own chance of this, stated with the estimate: 70%; the middle value lies beyond the limit too.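

In this assay compound 4 gives >= 11300 nM, which is a limit and not a number. Its steps to compound 1, compound 2 and compound 3 therefore cannot be read. The compounds shown leave open how strongly any of them inhibits and what phenyl in place of hydrogen on an amine nitrogen changes, because all of them stand at one mark: the limit of >= 11300 nM in this assay, at which 4 of the 4 values shown sit.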